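A few compounds are considered here, and "the series" means these few. Any claim that something is new, unique, unknown or untested is made for them only; others in the source may bear on it.

Among the compounds with values here, in a functional assay on HCT-116 cells (Homo sapiens) for inhibition, read by CCK-8 assay, with a stated time of 72 h, tested at 8 uM (a lower number here means less inhibition of growth, a higher number more inhibition of growth at the concentration tested), compound 2 (`COc1ccc(SCc2ccc(C(=O)Nc3ccccc3N)cc2)cc1`) gives 90.1% and stands highest of the three compounds measured so far. Compound 1 (`COc1ccc(SCc2ccc(/C=C/C(=O)Nc3ccccc3N)cc2)cc1OC`) gives 49.5% and compound 3 (`Nc1ccccc1NC(=O)/C=C/c1ccc(CSc2ccc(F)cc2)cc1`) gives 20.2% there, both lower than compound 2 by more than the scatter, and both have a core different from that of compound 2.

The next compound is compound 4 (`Cc1ccc(SCc2ccc(C(=O)Nc3ccccc3N)cc2)cc1`), which has methyl in place of methoxy on an aromatic carbon of a six-membered aromatic ring of carbon only, para to a large group (methyl in place of methoxy on an aromatic carbon). Within the data shown here, no measured pair shows this exact swap. Among the measured compounds shown here, only one measured step bears on it, and only indirectly: with 4-fluorophenyl in place of 3,4-dimethoxyphenyl on a sulfur, the result is a number 29.3 percentage points lower from compound 1 to compound 3 (beyond the scatter) on the other core.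

That lone step points downward, so starting from compound 2 at 90.1% a lower number is expected, though a milder fall than the one seen on the other core, and with wide uncertainty. The expected move is a number 12.1 percentage points lower from compound 2 to compound 4 (beyond the scatter) as a rough estimate. In this assay compound 4 is estimated at 78% within an expected range of 55% to 95% for now.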

Compound 4, percent growth inhibition at one concentration: 84%
Compound 4: the middle estimate sits 6 percentage points below what was measured, and the stated range covers the measured number.
By their numbers in this assay, from the lowest: compound 3; then compound 1; then compounds 4 and 2 (each within the scatter of the next).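

Within the data shown here, on the core of compound 2, this is the first pair that differs in one place, and in this assay the change from 4-methoxyphenyl to 4-methylphenyl gives a number 6.1 percentage points lower from compound 2 to compound 4 (within the scatter), so the two compounds cannot be told apart. The swap removes one oxygen and the one hydrogen-bond acceptor counted in methoxy, yet growth inhibition at the tested concentration stays within the scatter, which shows that, at this place on this core, this acceptor is not required to keep the reading. Nothing available explains why the two groups read alike.

Among these compounds, this single pair covers only two small groups at one place on the ring, so it remains open whether a much larger or charged group, such as an amine, a carboxylic acid or a longer chain, would be tolerated there as well. From the compounds shown here alone, it is also open whether methyl and methoxy would still read alike on the core of compound 1, or at concentrations other than the single one used here.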